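The compounds below may be only part of what the source reports. "The series", "measured", "known", "first", "only" and "open" are said of these compounds alone.

Compound 3, `CNC(=O)c1cc(C(=O)NC2CC2)cn(Cc2ccc(C)cc2)c1=O`, is the only one of the three measured compounds to give a plain number in a physicochemical assay for solubility; a lower number here means a less soluble compound, a higher number a more soluble compound: compound 3 gives 24 ug/mL. Compound 1, `CNC(=O)c1cc(C(=O)NC2CC2)cn(Cc2cccc([C@@H](C)O)c2)c1=O`, reaches a limit of the assay in this assay, >= 131 ug/mL. Compound 2, `CNC(=O)c1cc(C(=O)NC2CC2)cn(Cc2ccc(F)cc2)c1=O`, likewise reaches a limit in this assay, >= 162 ug/mL. The step of an at least 5.4-fold lower number from compound 1 to compound 3 (0.73 log units; beyond the scatter) and the step of an at least 6.7-fold lower number from compound 2 to compound 3 (0.82 log units; beyond the scatter) both lowered solubility when the group on the saturated chain carbon bound to an aromatic nitrogen was changed, while a step that the two limits leave unreadable from compound 1 to compound 2.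

Compound 4, `CNC(=O)c1cc(C(=O)NC2CC2)cn(Cc2cccc3occc23)c1=O`, differs from compound 3 at that same place: 1-benzofuran-4-yl in place of 4-methylphenyl on a saturated chain carbon bound to an aromatic nitrogen. The group that leaves and the group that enters both lack a hydrogen-bond donor, and the one that enters is the larger of the two. Since both measured steps at this place that could be read were lowering, compound 4 is expected to sit no higher than compound 3, with the step of a 1.7-fold lower number from compound 3 to compound 4 (0.23 log units; within the scatter) estimated as modest. Compound 4 is therefore estimated at 14 ug/mL, within a range from 4 ug/mL to 50 ug/mL.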

Compound 4, solubility: >= 110 ug/mL
Compound 4 ended at the assay's limit; the forecaster's own chance of this, stated with the estimate: 5%; at least 7.8-fold (0.89 log units) between middle value and limit.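

At this place, on a saturated chain carbon bound to an aromatic nitrogen, the result gives the first readable step upward in this assay: an at least 4.5-fold higher number from compound 3 to compound 4 (0.66 log units; beyond the scatter). The entering 1-benzofuran-4-yl is larger than the 4-methylphenyl that leaves and has 0 hydrogen-bond donors, so among these compounds a larger group without such a donor did not go with a lower number, and compound 3 remains the only one with a plain number. Compound 4 gives a limit of the assay, not a number, and the steps among compounds 1, 2 and 4 cannot be read: the limit of >= 110 ug/mL in this assay, at which 1 of the 4 values shown sits.

As far as these compounds go, how the values of compounds 1, 2 and 4 rank remains open. Also open, from the compounds shown here alone, is whether a 4-chlorophenyl or a 1-benzothiophen-4-yl at this place would give a low number like compound 3 or reach a limit like compound 4.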